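The source may report more compounds than this note shows. Statements on the series, on what has been measured and on what is new or still open speak of the compounds shown alone.

For the measured compounds named here, in an ADME assay on Caco-2 cells (Homo sapiens) for permeability, in the apical to basolateral direction (on this read-out lower numbers stand for lower permeability and higher numbers for higher permeability), compound 1 `O=C(Nc1cccnc1)c1cccc(Oc2ccc3c(c2)c(=O)ncn3Cc2c(F)cc(F)cc2F)c1C(F)(F)F` gives 0.26 10^-6 cm/s and compound 2 `O=C(Nc1ccccn1)c1cccc(Oc2ccc3c(c2)c(=O)ncn3Cc2c(F)cc(F)cc2F)c1C(F)(F)F` gives 1.2 10^-6 cm/s, the higher of the two numbers; the only step measured, a 4.6-fold higher number from compound 1 to compound 2 (0.66 log units; beyond the scatter), is a modest one. Compound 3 `O=c1ncn(Cc2c(F)cc(F)cc2F)c2ccc(Oc3cccc(-c4nc5ncccc5o4)c3C(F)(F)F)cc12` differs from compound 2 by a group of 9 heavy atoms (6 carbon, 2 nitrogen, 1 oxygen; one five-membered aromatic ring with 2 hetero atoms, one six-membered aromatic ring with 1 hetero atom) in place of a group of 9 heavy atoms (6 carbon, 2 nitrogen, 1 oxygen; one six-membered aromatic ring with 1 hetero atom), on an aromatic carbon. Going by the values given here, no measured step covers a change of this kind, since the one step seen only moved the attachment point of a pyridine, so the expectation rests on compound 2 alone, with wide uncertainty. For compound 3 the expected step is a 2.1-fold higher number from compound 2 to compound 3 (0.32 log units; beyond the scatter), giving an estimated value of 2.5 10^-6 cm/s, between 0.6 10^-6 cm/s and 10 10^-6 cm/s.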

Compound 3, apparent permeability: 3 10^-6 cm/s
Compound 3: middle estimate off by 1.2-fold (0.08 log units), on the low side; low and high end bracket the measured number.
By their numbers in this assay, from the lowest: compound 1; then compound 2; then compound 3.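

In this assay the step of a 2.5-fold higher number from compound 2 to compound 3 (0.40 log units; beyond the scatter) and the larger step of a 12-fold higher number from compound 1 to compound 3 (1.06 log units; beyond the scatter) both come with replacing the amide-containing group at this aromatic carbon, ortho to a trifluoromethyl group, by a group with a five-membered and a six-membered aromatic ring. For the compounds shown here, the amide hydrogen is therefore not needed at this position for the highest number so far. No measurement here explains the rise.

Still open, as far as these compounds go, is how a smaller group on this carbon, such as an amine or a carboxylic acid, would compare.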